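Aryl-chain variation on the chloroquinoline-type ether series

The source may report more compounds than this note shows. Statements on the series, on what has been measured and on what is new or still open speak of the compounds shown alone.

Measured compounds:
compound 1 `CCCCCCOc1ccc2c(Cl)ccnc2c1` — > 10000 nM
compound 2 `CCCCCCOc1ccc2c(NCCN(C)C)ccnc2c1` — 1860 nM
compound 3 `Clc1ccnc2cc(OCc3ccccc3)ccc12` — 5170 nM

In a functional assay on SK-OV-3 cells (Homo sapiens) for cytotoxicity, read by MTT assay, with a stated time of 48 h (on this read-out lower numbers stand for stronger inhibition and higher numbers for weaker inhibition), compound 1 gives only > 10000 nM, which is a limit of the assay and not a number; it sits at the limit of > 10000 nM in this assay, at which 1 of the 3 values shown sits. Two single changes to compound 1 have been measured. Compound 2 gives 1860 nM in this assay, a step of an at least 5.3-fold lower number from compound 1 to compound 2 (0.73 log units; beyond the scatter). Compound 3 gives 5170 nM in this assay, a step of an at least 1.9-fold lower number from compound 1 to compound 3 (0.28 log units; that floor lies within the scatter).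

Compound 4 `Clc1ccnc2cc(OCCCc3ccccc3)ccc12` is the next member. Its change from compound 1 is phenyl in place of propyl on a saturated chain carbon, three bonds along the chain from an oxygen on an aromatic ring. This is closest to the change that leads to compound 3, where phenyl replaced pentyl on a saturated chain carbon bound to an oxygen on an aromatic ring; the same kind of replacement, phenyl for an alkyl terminus, sits further along the chain here. Since compound 1 stands at a limit, the step to compound 3 is known only as a floor that lies within the scatter. The expectation for compound 4 is therefore a number near that of compound 3, and a step in this assay of an at least 2.0-fold lower number from compound 1 to compound 4 (0.30 log units; that floor lies within the scatter) is expected. The estimate for compound 4 in this assay is 5000 nM, with a range from 2000 nM to 20000 nM.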

Compound 4, half-maximal inhibitory concentration: 3610 nM
Compound 4: the middle estimate sits 1.4-fold (0.14 log units) above what was measured; the measured number falls inside the stated range.
By their numbers in this assay, from the lowest: compounds 2, 4 and 3 (each within the scatter of the next, the first and the last beyond it). At a limit, above all of these: compound 1.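

In this assay, phenyl in place of propyl on a saturated chain carbon, three bonds along the chain from an oxygen on an aromatic ring, gives an at least 2.7-fold lower number from compound 1 to compound 4 (0.44 log units; beyond the scatter). With the chloro group kept, a chain ending in phenyl now shows a floor beyond the scatter, which the step to compound 3 did not show. Compound 3 gives 5170 nM and compound 4 gives 3610 nM, values within the scatter of each other, so these two chain lengths cannot be told apart here. Compound 1 stands at a limit of the assay and not at a number, so the size of this step is known only as a floor: the limit of > 10000 nM in this assay, at which 1 of the 4 values shown sits.

Still open, as far as these compounds go, is how a longer chain ending in phenyl, or a pyridyl ring or a terminal amine in place of the phenyl, would read in this assay. Also open, from the compounds shown here alone, is whether the (2-(dimethylamino)ethyl)amino group of compound 2, set in place of chloro on the chain of compound 4, would lower the number further.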